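The source may report more compounds than this note shows. Statements on the series, on what has been measured and on what is new or still open speak of the compounds shown alone.

Compound 1 `CN(C)c1ccc2c(c1)N(S(C)(=O)=O)CC2CCl`: in a functional assay on CHO-AA8 cells (Cricetulus griseus) for cytotoxicity, with a stated time of 4 h (on this read-out lower numbers stand for stronger inhibition and higher numbers for weaker inhibition), compound 1 gives 72000 nM. Compound 2 `CSc1ccc2c(c1)N(S(C)(=O)=O)CC2CCl`: in this assay compound 2 gives > 200000 nM, which is a limit of the assay and not a number.

Compound 2 thus stands at the limit of > 200000 nM in this assay, at which 1 of the 2 values shown sits, with no number of its own. Going by the values given here, the only measured step, an at least 2.7-fold higher number from compound 1 to compound 2 (0.44 log units; beyond the scatter), concerned a group on the aromatic ring and says nothing about the sulfur that now changes. Compound 3 `CSSc1ccc2c(c1)N(S(C)(=O)=O)CC2CCl` differs from compound 2 by methylsulfanyl in place of methyl on a sulfur. Among the compounds with values here, no measured step bears on this change, so compound 3 is expected to remain at the limit, an expected step that the limit leaves unreadable from compound 2 to compound 3. The estimate for compound 3 is 250000 nM, within 100000 nM to 600000 nM.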

Compound 3, half-maximal inhibitory concentration: > 50000 nM
Compound 3 gave a limit, no number; the forecaster's own chance of this, stated with the estimate: 70%; the middle value does not contradict the limit.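

Going by these compounds alone, compound 3 returned only a limit of the assay, so no step from compound 1 or compound 2 to compound 3 can be read. The compounds shown leave open how methylsulfanyl in place of methyl on a sulfur alters the read-out in this assay.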